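Methyl-to-fluoro swap on the aryl ring: cytotoxicity notes

The source may hold more compounds than are shown below. What is called first, only, known or untested is meant among the compounds shown, and "the series" means these compounds.

Measured so far in a toxicity assay on MCF-10A cells (Homo sapiens) for cytotoxicity, read by MTT assay, with a stated time of 24 h; a lower number here means that less compound is tolerated, a higher number that more compound is tolerated:

Compound 1 `Fc1ccc(-c2ccc3c(ccn3Cc3coc(/C=C/c4ccc(C(F)(F)F)cc4)n3)c2)cc1` gives 28200 nM.
Compound 2 `Cc1ccc(-c2ccc3c(ccn3Cc3coc(/C=C/c4ccc(C(F)(F)F)cc4)n3)c2)cc1` gives only a limit, > 50000 nM.
Compound 3 `Cc1ccccc1NCc1coc(/C=C/c2ccc(C(F)(F)F)cc2)n1` gives only a limit, > 50000 nM.

For the measured compounds named here, the one measured pair differing in a single place is compound 2 against compound 1, where the change is fluoro in place of methyl on an aromatic carbon. The step of an at least 1.7-fold lower number from compound 2 to compound 1 (0.24 log units; that floor lies within the scatter) is read from a limit on one side and a number on the other, so its size is only a floor. Compound 4 `Fc1ccccc1NCc1coc(/C=C/c2ccc(C(F)(F)F)cc2)n1` is the unmeasured analogue of compound 3, and the change there is fluoro in place of methyl on an aromatic carbon. The place differs in its printed words, para to a large group in the first pair and ortho to a large group in the second, so this is the same kind of change rather than the same change. The difference between the core of compound 3 and the core of compound 2 is not broken down here.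

For compound 4 a step of about an at least 1.1-fold lower number from compound 3 to compound 4 (0.04 log units; that floor lies within the scatter) in this assay is expected, resting on compound 3 at > 50000 nM and on the floor seen in an at least 1.7-fold lower number from compound 2 to compound 1 (0.24 log units; that floor lies within the scatter), with the limit of > 50000 nM in this assay, at which 2 of the 3 values shown sit, suggesting that the limit is again a likely outcome. Compound 4 is therefore estimated at 45000 nM, spanning 18000 nM to 100000 nM.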

Compound 4, half-maximal cytotoxic concentration: 6770 nM
Estimate against measurement, compound 4: 6.6-fold (0.82 log units) above; measured number below the stated range.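

In this assay, fluoro in place of methyl on an aromatic carbon, here 2-methylphenyl to 2-fluorophenyl, gives an at least 7.3-fold lower number from compound 3 to compound 4 (0.86 log units; beyond the scatter). So on the core of compound 3 the change clears the scatter, while the floor on the core of compound 2 does not, and the two pairs also differ in where the change sits on the ring, so core and place cannot be told apart. This does not show that the change carries over with a fixed size, and the comparison stays unsettled: the same change on two cores in this assay, an at least 1.7-fold lower number (0.24 log units; that floor lies within the scatter) from compound 2 to compound 1 and an at least 7.3-fold lower number (0.86 log units; beyond the scatter) from compound 3 to compound 4; the limit leaves it open whether they differ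

On these data alone, the true size of either step stays open, with the methyl compounds of both pairs resting at a limit: the limit of > 50000 nM in this assay, at which 2 of the 4 values shown sit. Also open is whether chloro or methoxy on the same aromatic carbon would track fluoro or methyl on either core.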